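Methoxy added to the iodo analogue: expected tolerance

The source may hold more compounds than are shown below. What is called first, only, known or untested is meant among the compounds shown, and "the series" means these compounds.

Compound 1, `COc1ccc2c(=O)n(-c3ccc(Cl)cc3F)c(=O)oc2c1`, in an ADME assay on RAW264.7 cells (Mus musculus) for cytotoxicity, read by MTT assay, with a stated time of 24 h; a higher number here means that more compound is tolerated, a lower number that less compound is tolerated: > 40000 nM
Compound 2, `O=c1oc2ccccc2c(=O)n1-c1ccc(I)cc1F`, in this assay: 23600 nM

Of the compounds shown here, two have been measured. For compound 1 the value of > 40000 nM is a limit of the assay rather than a number. For the measured compounds named here, compound 2 gives 23600 nM in this assay, which is the only number in the set. The other entry, that of compound 1, is a limit, so no ordering between the two measured compounds can be drawn.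

The step from compound 2 to compound 3, `COc1ccc2c(=O)n(-c3ccc(I)cc3F)c(=O)oc2c1`, is methoxy in place of hydrogen on an aromatic carbon; that is, methoxy in place of hydrogen on an aromatic carbon. Going by the values given here, no step between two measured compounds is available, so the size of this change has no direct precedent here. Compound 1, which also carries the methoxy group, sits at the limit of > 40000 nM in this assay, at which 1 of the 2 values shown sits. For compound 3 the expected step of a 1.3-fold higher number from compound 2 to compound 3 (0.10 log units; within the scatter) is small and toward more tolerance, within the usual scatter. Compound 3 is therefore estimated at 30000 nM, with a range from 12000 nM to 75000 nM, and a fair chance that only a limit is reported.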

Compound 3, half-maximal cytotoxic concentration: 30100 nM
Estimate against measurement, compound 3: 1.0-fold (0.00 log units) below; measured number inside the range.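

In this assay, methoxy in place of hydrogen on this aromatic carbon, meta to a fused ring and para to a fused ring, now has a step of its own between two measured compounds, with iodo held fixed: a 1.3-fold higher number from compound 2 to compound 3 (0.11 log units; within the scatter). With the methoxy group held fixed, iodo in place of chloro gives the second step, an at least 1.3-fold lower number from compound 1 to compound 3 (0.12 log units; that floor lies within the scatter), and this figure is only a floor on the true size of the change. The entry of compound 1 is a limit of the assay and not a number: the limit of > 40000 nM in this assay, at which 1 of the 3 values shown sits.

The compounds shown leave open whether an amine or a carboxylic acid on this same aromatic carbon would move the number beyond the scatter, as methoxy does not here. They also leave open how large the change from chloro to iodo really is, and whether it would look the same on the shared core without the methoxy group.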